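Cyclopropylamino in place of isopropylamino on two cores

The compounds below may be only part of what the source reports. "The series", "measured", "known", "first", "only" and "open" are said of these compounds alone.

Measured so far in a functional assay on CHO-K1 cells for agonist activity at G-protein coupled receptor 6 (Homo sapiens), read by TR-FRET and cAMP accumulation, with a stated time of 20 h; a higher number here means that more compound is needed for the effect, a lower number that less compound is needed:
compound 1 `Cc1cc2nc(N3CCC(Oc4ccc(F)cc4F)CC3)c(NC3CC3)nc2cn1` gives 95000 nM
compound 2 `Cc1cc2nc(N3CCC(Oc4ccc(F)cc4F)CC3)c(NC(C)C)nc2cn1` gives 61000 nM
compound 3 `CC(=O)N1C=Cc2nc(NC(C)C)c(N3CCC(Oc4ccc(F)cc4F)CC3)nc2C1` gives 96000 nM

All three numbers are large and lie within the scatter of one another. From compound 2 to compound 1 the change is cyclopropyl in place of isopropyl on a nitrogen on an aromatic ring and the step it made is a 1.6-fold higher number from compound 2 to compound 1 (0.19 log units; within the scatter). Compound 3 carries a different core from compound 2; the difference between the two cores is not broken down here, and the two values differ by no more than the scatter.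

Compound 4 `CC(=O)N1C=Cc2nc(NC3CC3)c(N3CCC(Oc4ccc(F)cc4F)CC3)nc2C1` is compound 3 with the same change, (cyclopropyl in place of isopropyl on a nitrogen on an aromatic ring). Resting on that single precedent from compound 2 to compound 1, the step from compound 3 to compound 4 is expected to be small, about a 1.4-fold higher number from compound 3 to compound 4 (0.13 log units; within the scatter) in this assay. Compound 4 is therefore estimated at 130000 nM, most likely between 60000 nM and 300000 nM, with a real chance that this assay returns only a limit.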

Compound 4, half-maximal effective concentration: 34000 nM
For compound 4 the middle estimate is 3.8-fold (0.58 log units) above the measured one, outside the stated range (below it).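

In this assay the change from isopropylamino to cyclopropylamino gives a 2.8-fold lower number from compound 3 to compound 4 (0.45 log units; beyond the scatter), a step beyond the scatter, and the change does not carry over unchanged from the core of compound 1 to the core of compound 4: the same change on two cores in this assay, a 1.6-fold higher number (0.19 log units; within the scatter) from compound 2 to compound 1 and a 2.8-fold lower number (0.45 log units; beyond the scatter) from compound 3 to compound 4, 4.4-fold (0.64 log units) apart, beyond the scatter of two such steps. With one pair on each core, this shows that the size and direction of the step differ between these two cores, but it gives no reason for the difference and no rule for any further core. Even so, compound 4 gives 34000 nM, still a large number.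

Open, on these data alone, is whether cyclobutyl or a longer chain on a nitrogen on an aromatic ring would follow the same step on either core. Also open is which part of the core of compound 4 accounts for the difference.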